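The source may report more compounds than this note shows. Statements on the series, on what has been measured and on what is new or still open speak of the compounds shown alone.

Working notes on the series in an ADME assay on L02 cells (Homo sapiens) for cytotoxicity, read by MTT assay, with a stated time of 72 h; on this read-out lower numbers stand for stronger inhibition and higher numbers for weaker inhibition. Compound 1 `COc1cc(/C=C2\CNC/C(=C\c3cc(OC)c(OC)c(OC)c3)C2=O)cc(OC)c1OC` gives 7600 nM. Among the measured compounds shown here, compound 2 `COc1cc(/C=C2\CN(C)C/C(=C\c3cc(OC)c(OC)c(OC)c3)C2=O)cc(OC)c1OC` gives 26400 nM, and methyl in place of hydrogen on an amine nitrogen in a ring accounts for the only single-place step measured so far, a 3.5-fold higher number from compound 1 to compound 2 (0.54 log units; beyond the scatter). Compound 3 `CCCN1C/C(=C\c2ccc(OC)c(OC)c2)C(=O)/C(=C/c2ccc(OC)c(OC)c2)C1` carries a propyl chain and different aryl substitution, so it differs from compound 2 in more than one place. Compound 3 gives 21000 nM, within the scatter of compound 2. Compound 2 therefore sits with compound 3 at the upper end of the three numbers, and compound 1 lies clearly lower.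

Compound 4 `CCN1C/C(=C\c2cc(OC)c(OC)c(OC)c2)C(=O)/C(=C/c2cc(OC)c(OC)c(OC)c2)C1` differs from compound 2 by methyl in place of hydrogen on a saturated chain carbon bound to an amine nitrogen in a ring, which amounts to methyl to ethyl. The measured step from hydrogen to methyl, a 3.5-fold higher number from compound 1 to compound 2 (0.54 log units; beyond the scatter), is modest and does not itself cover a longer chain. Compound 3, at 21000 nM, gives only indirect support for a number that stays in the same region. No step beyond the scatter is therefore expected in this assay, and no direction is favoured. The estimated step is a 1.1-fold lower number from compound 2 to compound 4 (0.02 log units; within the scatter). For compound 4 the expected value is 25000 nM, with an estimated range of 12000 nM to 50000 nM.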

Compound 4, half-maximal inhibitory concentration: 12800 nM
Beside the measured number, compound 4's estimate is 2.0-fold (0.29 log units) above it, and the stated range covers the measured number.
By their numbers in this assay, from the lowest: compounds 1, 4, 3 and 2 (each within the scatter of the next, the first and the last beyond it).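

In this assay, the number does not rise steadily along the chain on the ring amine nitrogen: after a 3.5-fold higher number from compound 1 to compound 2 (0.54 log units; beyond the scatter) for methyl in place of hydrogen, the extension from methyl to ethyl runs the other way, giving a 2.1-fold lower number from compound 2 to compound 4 (0.31 log units; beyond the scatter). Ethyl in place of hydrogen on that nitrogen gives a 1.7-fold higher number from compound 1 to compound 4 (0.23 log units; within the scatter), so among hydrogen, methyl and ethyl on the shared core, only the methyl of compound 2 stands apart from the other two, and the effect of the first added carbon does not predict that of the second. No measurement at hand explains this turn in direction.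

As far as these compounds go, whether a butyl chain, a benzyl group or a carbonyl-bearing acetyl group on the same nitrogen would stay with compound 1 and compound 4 or move toward compound 2 remains open. Compound 3 carries a propyl chain, but it differs from compound 2 in more than one place, so it gives no clean reading of that chain on the shared core.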